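The source may report more compounds than this note shows. Statements on the series, on what has been measured and on what is new or still open speak of the compounds shown alone.

In an assay on OCI-Ly3 cells for activation of NF-kappa-B inhibitor alpha (Homo sapiens), read by a luciferase reporter (a lower number here means that less compound is needed, a higher number that more compound is needed for the effect), compound 3 `Cc1ccc2cccc(NS(=O)(=O)c3ccccc3N)c2n1` gives 8000 nM. Compound 1 `Cc1ccc2cccc(NS(=O)(=O)c3ccccc3[N+](=O)[O-])c2n1` gives 6800 nM, and compound 2 `COc1cc(NS(=O)(=O)c2ccc(C)cc2)c2nc(C)ccc2c1` gives 20000 nM; among these three numbers compound 3 sits close to compound 1, within the scatter, and apart from compound 2, beyond it. Compound 4 `Cc1ccc2cccc(NS(=O)(=O)c3ccc(Br)s3)c2n1` differs from compound 3 by 5-bromothiophen-2-yl in place of 2-aminophenyl on a sulfonyl sulfur. Among the compounds with values here, the only measured step touching this part of the molecule is a 1.2-fold higher number from compound 1 to compound 3 (0.07 log units; within the scatter), a change on the same ring that left the number within the scatter; no measured pair swaps the whole ring, so there is no direct guide for that. The expectation is therefore no change beyond the scatter, no change at the digits printed from compound 3 to compound 4 (within the scatter). Compound 4 is estimated at 8000 nM in this assay, between 2500 nM and 25000 nM.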

Compound 4, half-maximal effective concentration: 6100 nM
The estimate for compound 4 lay 1.3-fold (0.12 log units) above the measured number; the range from low to high includes it.
By their numbers in this assay, from the lowest: compounds 4, 1 and 3 (each within the scatter of the next); then compound 2.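

In this assay, the change to 5-bromothiophen-2-yl in place of 2-aminophenyl gives a 1.3-fold lower number from compound 3 to compound 4 (0.12 log units; within the scatter) on the sulfonyl sulfur. Within the data shown here, the earlier step altered only one group on the ring, whereas here the whole six-membered carbon ring gives way to a five-membered ring carrying sulfur and bromine, so this position accepts both aromatic groups without a change beyond the scatter. No measurement available here explains this. Still open, on these data alone, is whether a group without an aromatic ring, such as cyclohexyl or a butyl chain, would fit equally well on the sulfonyl sulfur.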